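Compound 1 to compound 3: removing the methoxy group

This account rests on a few compounds, and the source may have more. Where it says the series, first, only, none or still open, it means among the compounds named here.

- compound 1 `COc1ccc2[nH]c(-c3ccc[nH]3)c(C3CC(=O)NC3=O)c2c1` value 6000 nM
- compound 2 `c1ccc2[nH]c(-n3cccn3)cc2c1` value > 100000 nM (a limit, not a number)

Within the data shown here, in a functional assay on PC-3 cells (Homo sapiens) for cytotoxicity, read by MTT assay, with a stated time of 72 h (a lower number here means a stronger inhibitor, a higher number a weaker inhibitor), compound 1 gives 6000 nM as the only true number in the set. Compound 2 gives > 100000 nM as a limit of the assay and not a number.

The next compound to be read is compound 3 `O=C1CC(c2c(-c3ccc[nH]3)[nH]c3ccccc23)C(=O)N1` and the change from compound 1 is hydrogen in place of methoxy on an aromatic carbon which amounts to hydrogen in place of methoxy on an aromatic carbon. Among the measured compounds shown here, no measured step covers this change, so any expectation for it is poorly constrained. In this assay the expected 1.3-fold higher number from compound 1 to compound 3 (0.12 log units; within the scatter) is small and towards weaker inhibition, within or close to the scatter. With compound 1 at 6000 nM as the sole numerical anchor, the estimate stays near that value and the range is kept wide on both sides. For compound 3 the estimated value is 8000 nM with an expected range from 2500 nM to 30000 nM in this measurement.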

Compound 3, half-maximal inhibitory concentration: 9000 nM
Beside the measured number, compound 3's estimate is 1.1-fold (0.05 log units) below it; the range from low to high includes it.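

In this assay, among these compounds, hydrogen in place of methoxy on an aromatic carbon gives a 1.5-fold higher number from compound 1 to compound 3 (0.18 log units; within the scatter), the only step that can be read so far. The methoxy group is therefore not required for a true number at this place, on a six-membered aromatic ring of carbon only, meta to a fused ring and para to a fused ring: without it, compound 3 still gives 9000 nM. Compound 2 carries a limit of the assay and not a number, and it takes no part in this step: the limit of > 100000 nM in this assay, at which 1 of the 3 values shown sits.

A single exchange at a single place does not show whether another group there, such as an amine, a carboxylic acid or a longer alkoxy chain, would give a step beyond the scatter. No step shown touches the remaining parts of the core of compound 3, so what each of them contributes to the reading in this assay stays open.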